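Swapping the Aryl Group in a Cytotoxicity Series

The source may report more compounds than this note shows. Statements on the series, on what has been measured and on what is new or still open speak of the compounds shown alone.

Of the compounds shown here, two sharing one core have been measured so far. Compound 1, `C=CCn1c(=O)/c(=C\c2cc(F)ccc2C)[nH]c(=O)/c1=C\c1ccccc1OC`, gives 2900 nM in a functional assay on HeLa cells (Homo sapiens) for cytotoxicity, read by CCK-8 assay, with a stated time of 72 h; a lower number here means a stronger inhibitor, a higher number a weaker inhibitor. Going by the values given here, compound 2, `C=CCn1c(=O)/c(=C\c2cccc(Br)c2)[nH]c(=O)/c1=C\c1ccccc1OC`, gives 5400 nM in this assay, the higher of the two numbers; its only neighbour is compound 1, and the step of a 1.9-fold higher number from compound 1 to compound 2 (0.27 log units; within the scatter) stays within the scatter. Compound 3, `C=CCn1c(=O)/c(=C\c2ccc(C)cc2)[nH]c(=O)/c1=C\c1ccccc1OC`, has not been measured. It differs from compound 2 in one place: 4-methylphenyl in place of 3-bromophenyl on a double-bonded chain carbon bound to an aromatic carbon. Among the compounds with values here, the one measured step bears on this change, since it also exchanged the aryl group at the same place, and it moved the number little. On that basis no step beyond the scatter is expected for compound 3 in this assay. Compound 3 is expected at an estimated 4000 nM, with a range from 1500 nM to 11000 nM. The expected step is a 1.4-fold lower number from compound 2 to compound 3 (0.13 log units; within the scatter), within the scatter.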

Compound 3, half-maximal inhibitory concentration: "not active" (no number reported)
For compound 3 the study gives words and no number, so the estimate cannot be set against anything.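

Going by these compounds alone, compound 3 is reported only in words, as "not active", with no number, so no step from compound 2 to compound 3 can be read. No measured evidence bears on this result. The compounds shown leave open how much swapping 3-bromophenyl for 4-methylphenyl changes cytotoxicity.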